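This account rests on a few compounds, and the source may have more. Where it says the series, first, only, none or still open, it means among the compounds named here.

Within the data shown here, compound 1 `COc1cccc(NC(=S)N/N=C/c2ccc3ccccc3n2)c1` is the one entry with a number in a functional assay on HL-60 cells (Homo sapiens) for antiproliferative activity, read by sulforhodamine B assay, with a stated time of 72 h; a higher number here means a weaker inhibitor, a lower number a stronger inhibitor: compound 1 gives 71200 nM. Compound 2 `Cc1csc2sc(/C=N/NC(N)=S)c(C)c12` reaches only a limit, > 100000 nM. Compound 3 `CN(C)C(=S)N/N=C/c1cc2cccnc2s1` likewise stops at a limit, > 100000 nM. Among the measured compounds shown here, two of the three results therefore sit at the limit of > 100000 nM in this assay, at which 2 of the 3 values shown sit, and compound 1 stands as the only resolved value in the set. Compound 4 `COc1ccccc1NC(=S)N/N=C/c1ccc2ccccc2n1` has not been measured. Against compound 1 it differs in one place: 2-methoxyphenyl in place of 3-methoxyphenyl on an amide-type nitrogen. For the measured compounds named here, no measured pair shows what such a rearrangement does here, so the step from compound 1 to compound 4 is expected to stay within the scatter, with no direction claimed; the estimated step is a 1.1-fold higher number from compound 1 to compound 4 (0.05 log units; within the scatter). Compound 4 is thus expected near 80000 nM, between 30000 nM and 200000 nM, with a fair chance that only a limit is reported.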

Compound 4, half-maximal inhibitory concentration: 91700 nM
Estimate against measurement, compound 4: 1.1-fold (0.06 log units) below; the range from low to high includes it.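

Placing 2-methoxyphenyl in place of 3-methoxyphenyl on the amide-type nitrogen gives a 1.3-fold higher number from compound 1 to compound 4 (0.11 log units; within the scatter), the first step that can be read at this position in this assay. Moving the methoxy group around this phenyl ring therefore leaves the read-out unchanged within the scatter, and compound 4, like compound 1, returns a number rather than a limit. Both numbers still lie close to the ceiling of the assay: the limit of > 100000 nM in this assay, at which 2 of the 4 values shown sit.

Going by these compounds, it remains open whether any other group on this nitrogen can move the number beyond the scatter. A phenyl ring carrying a carboxylic acid or a morpholine would test this.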